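A few compounds are considered here, and "the series" means these few. Any claim that something is new, unique, unknown or untested is made for them only; others in the source may bear on it.

Measured so far:
compound 1, `CCCCOC(=O)NS(=O)(=O)c1sc(CC(C)C)cc1-c1ccc(CN2CCN(C)C2=O)cc1`: 16.5 nM in an assay on membranes from uterus for displacement of a labelled ligand from Angiotensin type II receptor (Sus scrofa), with a stated time of 1.5 h; on this read-out lower numbers stand for stronger inhibition and higher numbers for weaker inhibition
compound 2, `CCCCOC(=O)NS(=O)(=O)c1sc(CC(C)C)cc1-c1ccc(Cc2nnc(C(F)(F)F)o2)cc1`: 328 nM in this assay

Among the measured compounds shown here, compound 2 stands at the higher of the two numbers in this assay; the only measured step leading to it is a 20-fold higher number from compound 1 to compound 2 (1.30 log units; beyond the scatter), so compound 2 is the weaker of the two measured compounds. The next compound, compound 3, `CCCCOC(=O)NS(=O)(=O)c1sc(CC(C)C)cc1-c1ccc(Cn2ccc(C(F)(F)F)n2)cc1`, is not yet measured. It differs from compound 2 in one place: 3-(trifluoromethyl)-1H-pyrazol-1-yl in place of 5-(trifluoromethyl)-1,3,4-oxadiazol-2-yl on a saturated chain carbon bound to an aromatic carbon. For the measured compounds named here, the single measured step bears on this change only loosely: it replaced a saturated ring with an aromatic one and was large, whereas the step from compound 2 to compound 3 exchanges one five-membered aromatic ring bearing a trifluoromethyl group for another of the same size and hetero atom count minus one. Going by the values given here, no measured pair shows an exchange of this kind, so no strong movement in either direction can be expected from the data alone. The number for compound 3 in this assay is estimated at 220 nM, within 70 nM to 700 nM, that is an expected step of a 1.5-fold lower number from compound 2 to compound 3 (0.17 log units; within the scatter) that may well lie within the scatter.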

Compound 3, inhibition constant: 9.5 nM
Compound 3: the middle estimate sits 23-fold (1.36 log units) above what was measured; measured number outside the range, below it.
By their numbers in this assay, from the lowest: compounds 3 and 1 (each within the scatter of the next); then compound 2.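

In this assay, putting 3-(trifluoromethyl)-1H-pyrazol-1-yl in place of 5-(trifluoromethyl)-1,3,4-oxadiazol-2-yl on a saturated chain carbon bound to an aromatic carbon gives a 35-fold lower number from compound 2 to compound 3 (1.54 log units; beyond the scatter), so two five-membered aromatic rings with the same heavy-atom count, each bearing trifluoromethyl, are far from interchangeable at this position. The same aromatic group also stands level with the saturated 3-methyl-2-oxoimidazolidin-1-yl, with a 1.7-fold lower number from compound 1 to compound 3 (0.24 log units; within the scatter), which shows that the large step between the first two compounds cannot be read as the result of an aromatic ring as such taking the place of a saturated one. Nothing available here explains why the two aromatic rings differ so widely.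

The exchange alters the ring's hetero atoms and its point of attachment together, so the compounds shown cannot separate these two changes. Going by these compounds, it also remains open how the 1H-pyrazol-1-yl ring would fare with a methyl group or a carboxylic acid in place of trifluoromethyl.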